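A few compounds are considered here, and "the series" means these few. Any claim that something is new, unique, unknown or untested is made for them only; others in the source may bear on it.

Measured in a physicochemical assay for solubility, in phosphate buffer, with a stated time of 18 h; on this read-out lower numbers stand for lower solubility and higher numbers for higher solubility
compound 1 `Cc1nc(C(C)(C)C)nc2nc(N)c(C#N)c(N)c12` gives 37000 nM
compound 2 `CC(C)(C)c1nc(CCCCC#N)c2c(N)c(C#N)c(N)nc2n1` gives 16000 nM
compound 3 `CC(C)(C)c1nc(-c2ccc(C(=O)O)s2)c2c(N)c(C#N)c(N)nc2n1` gives > 1000000 nM as a limit of the assay and not a number

Compound 3 is known only as a limit (the limit of > 1000000 nM in this assay, at which 1 of the 3 values shown sits). Compound 4 `CC(C)(C)c1nc(-c2ccn[nH]2)c2c(N)c(C#N)c(N)nc2n1` carries 1H-pyrazol-5-yl in place of 5-carboxythiophen-2-yl on an aromatic carbon.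

Two large steps bear on this change, since both bring 5-carboxythiophen-2-yl onto that carbon (an at least 27-fold higher number from compound 1 to compound 3 (1.43 log units; beyond the scatter); an at least 62-fold higher number from compound 2 to compound 3 (1.79 log units; beyond the scatter)). The step between the two compounds without that group is only modest (a 2.3-fold lower number from compound 1 to compound 2 (0.36 log units; beyond the scatter)). Compound 4 also lacks 5-carboxythiophen-2-yl, so a large step to a lower number is expected in this assay (an at least 50-fold lower number from compound 3 to compound 4 (1.69 log units; beyond the scatter)). Among the measured compounds shown here, no measured compound carries 1H-pyrazol-5-yl, so the expected range stays wide and is anchored on compound 1 (37000 nM) and compound 2 (16000 nM). The estimated value for compound 4 is 20000 nM with an expected range from 3000 nM to 120000 nM in this assay (to be checked by measurement).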

Compound 4, solubility: 13500 nM
For compound 4 the middle estimate is 1.5-fold (0.17 log units) above the measured one; the range from low to high includes it.
By their numbers in this assay, from the lowest: compounds 4 and 2 (each within the scatter of the next); then compound 1. At a limit, above all of these: compound 3.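

In this assay, 1H-pyrazol-5-yl on this aromatic carbon in place of 5-carboxythiophen-2-yl gives an at least 74-fold lower number from compound 3 to compound 4 (1.86 log units; beyond the scatter), so a five-membered aromatic ring at this position is not enough to hold the read-out at the limit. The number instead stays in the range of the compounds with saturated chains here: a 1.2-fold lower number from compound 2 to compound 4 (0.07 log units; within the scatter), and a 2.7-fold lower number from compound 1 to compound 4 (0.44 log units; beyond the scatter). Compound 3 remains a limit and not a number, so the full size of its step stays unknown: the limit of > 1000000 nM in this assay, at which 1 of the 4 values shown sits.

The compounds shown do not separate the thiophene ring from its carboxylic acid, so thiophen-2-yl without the acid, or a pyrazole carrying a carboxylic acid, would be needed to tell which part goes with the step. From the compounds shown here alone, how an amine or a saturated chain ending in a carboxylic acid reads on this carbon in this assay also stays open.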